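Acetal aryl swap in a dimethoxy bicyclic series

A few compounds are considered here, and "the series" means these few. Any claim that something is new, unique, unknown or untested is made for them only; others in the source may bear on it.

Measured so far in a functional assay on HEL cells (Homo sapiens) for cytotoxicity; on this read-out lower numbers stand for higher toxicity in this test and higher numbers for lower toxicity in this test:
compound 1 `O[C@@H]1[C@@H](O)[C@H](c2ccccc2)O[C@@H]2CO[C@@H](c3ccc(Cl)cc3)O[C@@H]12`: > 50 ug/mL
compound 2 `O[C@@H]1[C@@H](O)[C@H](c2ccccc2)O[C@@H]2CO[C@@H](c3ccc4ccccc4c3)O[C@@H]12`: 21 ug/mL
compound 3 `CO[C@@H]1[C@@H](OC)[C@H](c2ccccc2)O[C@@H]2CO[C@@H](Cc3ccccc3)O[C@@H]12`: "not determined" (no result reported)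

Compound 1 sits at a limit of this assay, (the limit of > 50 ug/mL in this assay, at which 1 of the 3 values shown sits), so no number is known for it. Compound 2 gives 21 ug/mL in this assay. For compound 3 the entry in this assay reads "not determined" (no result reported); it stands without a number, and so it gives no anchor of its own.

Compound 4 `CO[C@@H]1[C@@H](OC)[C@H](c2ccccc2)O[C@@H]2CO[C@@H](c3ccc4ccccc4c3)O[C@@H]12` is the next compound. It differs from compound 3 in one place: naphthalen-2-yl in place of benzyl on a saturated ring carbon. Going by the values given here, no step between measured compounds covers this change, so its size cannot be read off directly. Among the compounds with values here, the only measured compound bearing naphthalen-2-yl is compound 2, with 21 ug/mL in this assay, and that value is the nearest guide. Compound 4 is therefore expected to give a number in this assay rather than a limit, estimated at 20 ug/mL with a likely span from 8 ug/mL to 50 ug/mL.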

Compound 4, half-maximal cytotoxic concentration: > 50 ug/mL
Compound 4 ended at the assay's limit; the forecaster's own chance of this, stated with the estimate: 25%; middle value at least 2.5-fold (0.39 log units) away from the limit.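

Going by these compounds alone, compound 3 carries no number in this assay, so no step to compound 4 can be read. Compound 4 gives > 50 ug/mL, which is a limit of the assay and not a number. Going by these compounds, the size of any effect of exchanging benzyl for naphthalen-2-yl in this assay stays open.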